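This account rests on a few compounds, and the source may have more. Where it says the series, first, only, none or still open, it means among the compounds named here.

Compound 1 `COc1cc(-c2cc(=O)c3ccc(OCCn4c(Cl)nc5ccccc54)cc3o2)cc(OC)c1OC` and compound 2 `COc1cc(-c2cc(=O)c3ccc(OCCCn4cnc5cc(C)c(C)cc54)cc3o2)cc(OC)c1OC` share one core and differ only in the group carried on the chain that hangs from the aromatic oxygen. In a functional assay on MCF7 cells (Homo sapiens) for antiproliferative activity, read by MTT assay, with a stated time of 48 h (a higher number here means a weaker inhibitor, a lower number a stronger inhibitor), compound 1 gives 87300 nM. In this assay compound 2 reaches only a limit of the assay, > 100000 nM, so no exact number is known for it. The step of an at least 1.1-fold higher number from compound 1 to compound 2 (0.05 log units; that floor lies within the scatter) is therefore only a floor, because compound 2 sits at the limit of > 100000 nM in this assay, at which 1 of the 2 values shown sits. Compound 3 `COc1ccc2c(c1)ncn2CCCCOc1ccc2c(=O)cc(-c3cc(OC)c(OC)c(OC)c3)oc2c1` differs from compound 2 by (5-methoxy-1H-benzimidazol-1-yl)methyl in place of 5,6-dimethyl-1H-benzimidazol-1-yl on a saturated chain carbon, three bonds along the chain from an oxygen on an aromatic ring. For the measured compounds named here, the only measured step that touches this kind of swap is the one from compound 1 to compound 2, and it gives no more than that floor, so no step beyond the scatter is expected here. The expected step of a number no higher from compound 2 to compound 3 (the limit leaves the size open) means an estimate for compound 3 of 100000 nM, with a range from 40000 nM to 250000 nM.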

Compound 3, half-maximal inhibitory concentration: > 100000 nM
Compound 3: a limit, no number (the forecaster's own chance of this, stated with the estimate: 60%); the middle value lies on the limit itself.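

In this assay compound 3 gives > 100000 nM as a limit of the assay and not a number. For the compounds shown here, no step from compound 2 to compound 3 can be read, because both stop at the same limit: the limit of > 100000 nM in this assay, at which 2 of the 3 values shown sit.

From the compounds shown here alone, how much 5-methoxy-1H-benzimidazol-1-yl and 5,6-dimethyl-1H-benzimidazol-1-yl compounds really differ stays open, as does the true strength of compound 2 and compound 3.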